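Removing the Isopropyl Group: What Paw Edema May Show

The source may report more compounds than this note shows. Statements on the series, on what has been measured and on what is new or still open speak of the compounds shown alone.

Compound 1 `O=C1CC(c2ccccc2OCc2ccc(F)cc2)Oc2ccccc21` gives 18.2% in a functional assay on the whole organism (strain Sprague-Dawley) for inhibition, with Rattus norvegicus as the target, read by paw edema, with stated times of 1 h and 3 h, at a dose of 150 umol/kg by the oral route; a lower number here means less inhibition, a higher number more inhibition at the dose given (going by the name of the read-out).
Compound 2 `CC(C)c1ccc(COc2ccccc2C2CC(=O)c3ccccc3O2)cc1` gives 18% in this assay.

Among the measured compounds shown here, compound 2 stands lowest of the two numbers, though the single measured step, a number 0.2 percentage points lower from compound 1 to compound 2 (within the scatter), lies within the scatter, so the two compounds cannot be ordered. Compound 3 `O=C1CC(c2ccccc2OCc2ccccc2)Oc2ccccc21` carries the change (hydrogen in place of isopropyl on an aromatic carbon). For the measured compounds named here, no measured step removes a group to leave hydrogen, so only the step from compound 1 to compound 2 bears on it, and that step was flat. The expected step is therefore none beyond the scatter, no change at the digits printed from compound 2 to compound 3 (within the scatter). Compound 3 is estimated at 18%, between 8% and 28%.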

Compound 3, a percentage reported as inhibition, in the whole organism at one dose (the size of the read-out at that dose, not a potency): 9.8%
Estimate against measurement, compound 3: 8.2 percentage points above; measured number inside the range.
By their numbers in this assay, from the lowest: compounds 3, 2 and 1 (each within the scatter of the next).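

In this assay hydrogen in place of isopropyl gives a number 8.2 percentage points lower from compound 2 to compound 3 (within the scatter) and hydrogen in place of fluoro gives a number 8.4 percentage points lower from compound 1 to compound 3 (within the scatter) as the second reading. With a bare hydrogen added to the comparison, isopropyl, fluoro and hydrogen at this position still cannot be told apart, so no group here is shown to matter for the reading. No measured evidence bears on this result. The compounds shown leave open whether an amine or a carboxylic acid at this position would move the number beyond the scatter.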